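Swapping chloro for methyl on a bromophenyl-bearing core

A few compounds are considered here, and "the series" means these few. Any claim that something is new, unique, unknown or untested is made for them only; others in the source may bear on it.

Compound 1 `Nc1cc(-c2ccc(Br)cc2)nc2cc(-c3ccc(Cl)cc3)nn12` and compound 3 `Nc1cc(-c2ccc(Cl)cc2)nc2cc(-c3ccc(Br)cc3)nn12` are built from the same atoms joined differently; how their two cores differ is not broken down here. In a functional assay on the whole organism (strain Wistar) for inhibition, with Rattus norvegicus as the target, read by paw edema, with stated times of 30 min and 2 h, at a dose of 50 mg/kg by the oral route (on this read-out higher numbers stand for more inhibition at the one dose given (going by the name of the read-out) and lower numbers for less inhibition), compound 1 gives 60%, and compound 3 gives 72.5%. Compound 2 `Cc1ccc(-c2cc3nc(-c4ccc(Br)cc4)cc(N)n3n2)cc1` arises from compound 1 by the change (methyl in place of chloro on an aromatic carbon), and in this assay compound 2 gives 56.3%, so the step was a number 3.7 percentage points lower from compound 1 to compound 2 (within the scatter). Compound 4 `Cc1ccc(-c2cc(N)n3nc(-c4ccc(Br)cc4)cc3n2)cc1` has not yet been measured; it arises from compound 3 by the same change, (methyl in place of chloro on an aromatic carbon), at the same place. Because the earlier step of a number 3.7 percentage points lower from compound 1 to compound 2 (within the scatter) stayed within the scatter, a similarly small step is expected this time, a number 3.5 percentage points lower from compound 3 to compound 4 (within the scatter). Compound 4 is therefore estimated to give 69% in this assay, somewhere between 56% and 80%.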

Compound 4, a percentage reported as inhibition, in the whole organism at one dose (the size of the read-out at that dose, not a potency): 76.3%
Beside the measured number, compound 4's estimate is 7.3 percentage points below it; low and high end bracket the measured number.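

In this assay, the swap from 4-chlorophenyl to 4-methylphenyl on the second core gives a number 3.8 percentage points higher from compound 3 to compound 4 (within the scatter). Set beside the same swap on the first core, the two steps show no difference that stands out from the ordinary spread of such measurements, so in this series the change carries over from one core to the other as a small step: the same change on two cores in this assay, a number 3.7 percentage points lower (within the scatter) from compound 1 to compound 2 and a number 3.8 percentage points higher (within the scatter) from compound 3 to compound 4, 7.5 percentage points apart, within the scatter of two such steps This rests on only two pairs of compounds at a single dose, so it does not show that the swap would stay small on any other core.

The compounds shown leave open whether a different group in the same place, such as an amine or a carboxylic acid, would give a step beyond the scatter. They also leave open whether such a group would behave alike on both cores.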